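Swapping an ortho chloro for methyl on the benzamide ring

The compounds below may be only part of what the source reports. "The series", "measured", "known", "first", "only" and "open" are said of these compounds alone.

Measured compounds:
compound 1 `O=C(NC(=S)NNc1ncnc2ccccc12)c1cccc(Cl)c1` gives 4540 nM
compound 2 `COc1ccccc1C(=O)NC(=S)NNc1ncnc2ccccc12` gives 14300 nM
compound 3 `O=C(NC(=S)NNc1ncnc2ccccc12)c1ccccc1Cl` gives 9140 nM

All three share the same core and differ only in the ring attached to the carbonyl carbon. In a functional assay on MGC-803 cells (Homo sapiens) for cytotoxicity, read by MTT assay, with a stated time of 72 h (on this read-out lower numbers stand for stronger inhibition and higher numbers for weaker inhibition), compound 3 stands second highest of the three numbers; its nearest neighbour is compound 2 and its furthest is compound 1, and both of those gaps lie within the scatter.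

Compound 4 `Cc1ccccc1C(=O)NC(=S)NNc1ncnc2ccccc12` has not yet been measured. It differs from compound 3 by methyl in place of chloro on an aromatic carbon.

For the measured compounds named here, no measured step exchanges chloro for methyl, so the only guidance comes indirectly. The step of a 1.6-fold lower number from compound 2 to compound 3 (0.19 log units; within the scatter) shows that replacing one small group by another at this same aromatic carbon moved the number only within the scatter, and the step of a 2.0-fold higher number from compound 1 to compound 3 (0.30 log units; within the scatter) shows that moving chloro around the ring also stayed within the scatter. Going by the values given here, the one step beyond the scatter, a 3.1-fold higher number from compound 1 to compound 2 (0.50 log units; beyond the scatter), involved a different pairing. On this basis the expected step in this assay is a 1.1-fold higher number from compound 3 to compound 4 (0.04 log units; within the scatter), that is, none beyond the scatter. The estimate for compound 4 is therefore 10000 nM, with a range from 4000 nM to 25000 nM.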

Compound 4, half-maximal inhibitory concentration: 4240 nM
Estimate against measurement, compound 4: 2.4-fold (0.37 log units) above; the measured number falls inside the stated range.
By their numbers in this assay, from the lowest: compounds 4, 1, 3 and 2 (each within the scatter of the next, the first and the last beyond it).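

In this assay, methyl in place of chloro on this aromatic carbon, ortho to a large group, gives a 2.2-fold lower number from compound 3 to compound 4 (0.33 log units; beyond the scatter), so a change of one heavy atom here can move the number beyond the scatter, which the step between methoxy and chloro, a 1.6-fold lower number from compound 2 to compound 3 (0.19 log units; within the scatter), did not show. Methyl in place of methoxy on the same carbon gives a 3.4-fold lower number from compound 2 to compound 4 (0.53 log units; beyond the scatter), so methyl stands apart from both other groups tried at this position, while the change of the whole ring gives a 1.1-fold lower number from compound 1 to compound 4 (0.03 log units; within the scatter), which means that the 2-methylphenyl ring and the 3-chlorophenyl ring cannot be told apart in this assay. Nothing measured here accounts for the difference between methyl and the other two groups, so the numbers show the size of the change but not its cause.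

As far as these compounds go, it remains open whether a longer chain such as ethyl, or an amine or a carboxylic acid, on this carbon would keep the number near that of compound 4. From the compounds shown here alone, it is also open whether methyl would act the same way on the ring carbon that carries chloro in compound 1.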